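A Cyclohexyl Group Added Where Three Analogues Show Only Limits

The source may report more compounds than this note shows. Statements on the series, on what has been measured and on what is new or still open speak of the compounds shown alone.

Compound 1 `COc1ccc(C(O)C2OC(=O)c3c(OC)cc(OC)cc32)cc1` serves as the reference. In an ADME assay on RAW264.7 cells (Mus musculus) for cytotoxicity, read by MTT assay, with a stated time of 24 h, in the presence of a further agent that is not named here (on this read-out higher numbers stand for weaker inhibition and lower numbers for stronger inhibition), compound 1 gives only a limit of the assay, > 40000 nM. Compound 2 `COCCCOc1ccc(C(O)C2OC(=O)c3c(OC)cc(OC)cc32)cc1` gives only a limit in this assay as well, > 40000 nM. Compound 3 `COCCCCOc1ccc(C(O)C2OC(=O)c3c(OC)cc(OC)cc32)cc1` likewise returns nothing more than a limit, > 40000 nM. Consequently none of the three measured comparisons can be read as a number: a step that the two limits leave unreadable from compound 1 to compound 2, a step that the two limits leave unreadable from compound 1 to compound 3 and a step that the two limits leave unreadable from compound 2 to compound 3 are all of unreadable size, because every value sits at the limit of > 40000 nM in this assay, at which 3 of the 3 values shown sit. Compound 1 therefore stands at the limit, neither above nor below its two companions on any reading the data allow.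

Compound 4 `COc1cc(OC)c2c(c1)C(C(O)c1ccc(OCC3CCCCC3)cc1)OC2=O` differs from compound 1 in a single place: cyclohexyl in place of hydrogen on a saturated chain carbon bound to an oxygen on an aromatic ring. The three measured steps bear on it only in the sense that they all start from, or end at, the same saturated chain carbon bound to an oxygen on the aromatic ring, and none of them moved any value off the limit. Compound 4 is therefore expected to behave like its three relatives, with an estimated step that the limit leaves unreadable from compound 1 to compound 4. The estimate for compound 4 in this assay is 50000 nM, within a range from 20000 nM to 150000 nM, and it is expected that the assay will most likely again report only a limit.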

Compound 4, half-maximal inhibitory concentration: > 40000 nM
Compound 4: no number, only a limit (the forecaster's own chance of this, stated with the estimate: 80%); the middle value does not contradict the limit.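

Compound 4 also returns only a limit, so no step linking it to compound 1, compound 2 or compound 3 can be read, because all four compounds sit at the same limit: the limit of > 40000 nM in this assay, at which 4 of the 4 values shown sit.

The compounds shown leave open whether cyclohexyl, 2-methoxyethyl or 3-methoxypropyl in place of hydrogen changes cytotoxicity at all, and how the four compounds rank.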